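From 1-aminoethyl to pyrrolidin-2-yl: one step awaiting measurement

This account rests on a few compounds, and the source may have more. Where it says the series, first, only, none or still open, it means among the compounds named here.

Within the data shown here, only two compounds have been measured so far. In a physicochemical assay for solubility, in phosphate buffer, at pH 7.0 (a higher number here means a more soluble compound, a lower number a less soluble compound), compound 1 (`COc1ccc(O)c(-c2csc(N/N=C(/C)C3CCc4ccccc43)n2)c1`) gives < 50000 nM as a limit of the assay and not as a number. Among the measured compounds shown here, compound 2 (`C/C(=N\Nc1nc([C@H](C)N)cs1)c1ccc2c(c1)CCC2`) gives 700000 nM in this assay and so holds the only actual number in the set. Compound 3 (`C/C(=N\Nc1nc([C@@H]2CCCN2)cs1)c1ccc2c(c1)CCC2`) has not yet been measured. It differs from compound 2 in one place, with pyrrolidin-2-yl in place of 1-aminoethyl on an aromatic carbon. The new group stands on the same ring position, next to the ring nitrogen and two ring bonds from the ring sulfur. For the measured compounds named here, no measured pair of compounds shows a change of this kind, so the data offer no direct guide to its size. The expectation therefore starts from compound 2 at 700000 nM as its only anchor. The estimated 1.4-fold lower number from compound 2 to compound 3 (0.15 log units; within the scatter) is expected to stay within the usual scatter of this assay and to show no clear direction. For compound 3 the expected solubility is 500000 nM with an estimated range from 200000 nM to 1000000 nM in this measurement.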

Compound 3, solubility: 900000 nM
For compound 3 the middle estimate is 1.8-fold (0.26 log units) below the measured one, within the range that was stated.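

In this assay the change from 1-aminoethyl, which has no ring, to pyrrolidin-2-yl, a five-membered non-aromatic ring, gives a 1.3-fold higher number from compound 2 to compound 3 (0.11 log units; within the scatter) and shows no direction that can be read. Among these compounds, this is the first step in the set that can be read at all, and it shows that 3 heavy atoms can give way to 5 at this place, next to the ring nitrogen and two ring bonds from the ring sulfur, without separating the two compounds in this read-out, while the counts of hydrogen-bond donors and acceptors stay the same. Nothing shown here gives a cause for this outcome.

A single step cannot say whether a six-membered ring such as piperidin-2-yl, or a quite different group such as a carboxylic acid, would behave the same way at this position. It also leaves open what the opposite stereocentre of pyrrolidin-2-yl would give in this assay and whether the same exchange would read alike on a different core.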